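A few compounds are considered here, and "the series" means these few. Any claim that something is new, unique, unknown or untested is made for them only; others in the source may bear on it.

In a functional assay on A549 cells (Homo sapiens) for inhibition, read by sulforhodamine B assay (a higher number here means a weaker inhibitor of growth, a lower number a stronger inhibitor of growth), compound 1 (`Fc1ccc(-c2ccc(-c3ccc(-c4nc5ccccc5[nH]4)cc3)cc2)cc1`) gives 33200 nM and compound 2 (`Clc1cccc(-c2ccc(-c3ccc(-c4nc5ccccc5[nH]4)cc3)cc2)c1`) gives 31100 nM as the second of the two measured values. Compound 2 therefore stands level with compound 1, and neither can be ranked above the other. Compound 3 (`COc1ccc(-c2ccc(-c3ccc(-c4nc5ccccc5[nH]4)cc3)cc2)cc1OC`) keeps the shared core and has 3,4-dimethoxyphenyl in place of 3-chlorophenyl on an aromatic carbon, para to a large group (3,4-dimethoxyphenyl in place of 3-chlorophenyl on an aromatic carbon). Among the compounds with values here, only one measured step bears on this change: a 1.1-fold lower number from compound 1 to compound 2 (0.03 log units; within the scatter) with 3-chlorophenyl in place of 4-fluorophenyl. Within the data shown here, that exchange of one substituted phenyl for another left the growth-inhibition reading unchanged, but it is a single step, and no measured compound carries a methoxy group. On that thin basis, no shift beyond the scatter is expected in this assay and no direction can be favoured. The estimated step is a 1.0-fold lower number from compound 2 to compound 3 (0.02 log units; within the scatter) and the range is kept wide on both sides. Compound 3 is estimated at 30000 nM (expected range 12000 nM to 65000 nM).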

Compound 3, concentration for 50% growth inhibition: 7600 nM
Beside the measured number, compound 3's estimate is 3.9-fold (0.60 log units) above it; the whole stated range lies above it.
By their numbers in this assay, from the lowest: compound 3; then compounds 2 and 1 (each within the scatter of the next).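

Notes on the series: the terminal ring at this position, on an aromatic carbon para to a large group, is not silent in this assay, as 3,4-dimethoxyphenyl gives a 4.1-fold lower number from compound 2 to compound 3 (0.61 log units; beyond the scatter) and, against the fluorinated comparator, a 4.4-fold lower number from compound 1 to compound 3 (0.64 log units; beyond the scatter) on the same core. Within the data shown here, the only earlier exchange, between the two halogen-bearing phenyl groups, gave a 1.1-fold lower number from compound 1 to compound 2 (0.03 log units; within the scatter), so this is the first change at the position that moves the reading beyond the scatter, and it does so in the direction of stronger growth inhibition from both starting points. Nothing at hand accounts for this gain, and the larger size of the entering group and its oxygen atoms cannot be told apart as the relevant difference.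

Open, as far as these compounds go, is whether both methoxy groups are needed, or whether a single methoxy group at either of the two ring positions would give the same reading. Also open, from the compounds shown here alone, is whether other oxygen- or nitrogen-bearing substituents on this ring, such as a hydroxyl group, a dimethylamino group or a longer ethoxy chain, would follow the same course in this cell line.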